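This account rests on a few compounds, and the source may have more. Where it says the series, first, only, none or still open, it means among the compounds named here.

Compound 1 `Cc1ccc(S(=O)(=O)NC(C)C)cc1C#Cc1cc(Cl)ccc1OCC(=O)O` and compound 2 `CCN(CC)S(=O)(=O)c1ccc(C)c(C#Cc2cc(Cl)ccc2OCC(=O)O)c1` share a core and differ only at the sulfonyl sulfur. In an assay on CHO cells for displacement of a labelled ligand from prostaglandin D2 receptor 2 (Homo sapiens), read by scintillation counting (on this read-out higher numbers stand for weaker inhibition and lower numbers for stronger inhibition), compound 1 gives 3.4 nM, and in this assay compound 2 gives 3.4 nM. The step of no change at the digits printed from compound 1 to compound 2 (within the scatter) shows that exchanging one amine on that sulfur for another left the value where it was. Compound 3 `Cc1ccc(S(=O)(=O)N(C)CCN(C)C)cc1C#Cc1cc(Cl)ccc1OCC(=O)O` takes the same route: (2-(dimethylamino)ethyl)(methyl)amino in place of diethylamino on a sulfonyl sulfur, the difference reading diethylsulfamoyl to (2-(dimethylamino)ethyl)(methyl)sulfamoyl one bond further out. Among the measured compounds shown here, since the only comparable step no change at the digits printed from compound 1 to compound 2 (within the scatter) stayed within the scatter, the expected step here is a 1.2-fold higher number from compound 2 to compound 3 (0.07 log units; within the scatter). Compound 3 is therefore estimated at 4 nM, between 1.5 nM and 12 nM.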

Compound 3, inhibition constant: 369 nM
Beside the measured number, compound 3's estimate is 92-fold (1.96 log units) below it; measured number outside the range, above it.
By their numbers in this assay, from the lowest: compounds 1 and 2 (each within the scatter of the next); then compound 3.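

The sulfonyl sulfur does not accept every amine equally: in this assay, the swap to (2-(dimethylamino)ethyl)(methyl)amino gives a 110-fold higher number from compound 2 to compound 3 (2.04 log units; beyond the scatter) and likewise a 110-fold higher number from compound 1 to compound 3 (2.04 log units; beyond the scatter). The tolerance seen between isopropylamino and diethylamino therefore does not extend to this group. Nothing measured here accounts for the loss. Still open, on these data alone, is whether the dimethylamino part carries the loss or the chain as a whole. A methoxyethyl chain on the same sulfur would help separate the two, and a morpholine would show how a ring fares there.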